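Carbamate chain variation on the shared core: cytotoxicity notes

The source may report more compounds than this note shows. Statements on the series, on what has been measured and on what is new or still open speak of the compounds shown alone.

Measured so far:
- compound 1 `CC(C)COC(=O)Nc1ccc([Se]C#N)cc1`: 49500 nM
- compound 2 `C=CCOC(=O)Nc1ccc([Se]C#N)cc1`: 47400 nM
- compound 3 `CCCCOC(=O)Nc1ccc([Se][Se]c2ccc(NC(=O)OCCCC)cc2)cc1`: 49600 nM

In an ADME assay on BEAS-2B cells (Homo sapiens) for cytotoxicity, read by MTT assay, with a stated time of 72 h (a higher number here means a weaker inhibitor of growth, a lower number a stronger inhibitor of growth), compound 2 gives 47400 nM, the lowest of the three numbers, though its gaps to compound 1 and to compound 3 are both within the scatter, so no order among the three can be read from these values.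

Compound 4 `CCOC(=O)Nc1ccc([Se]C#N)cc1` has not yet been measured. It differs from compound 2 by methyl in place of vinyl on a saturated chain carbon bound to an oxygen next to a carbonyl group.

Among the compounds with values here, the one measured step that bears on this change is a 1.0-fold lower number from compound 1 to compound 2 (0.02 log units; within the scatter), a change of the same kind at the same place that left the number essentially unchanged. Compound 3, with a different chain on its core, sits in the same range as well. On this basis, no step beyond the scatter is expected in this assay from compound 2 to compound 4, with a 1.0-fold higher number from compound 2 to compound 4 (0.01 log units; within the scatter) as the estimated change.

Compound 4 is therefore estimated at 48000 nM, with a range of 30000 nM to 76000 nM.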

Compound 4, concentration for total growth inhibition: 46900 nM
Compound 4: middle estimate off by 1.0-fold (0.01 log units), on the high side; the measured number falls inside the stated range.
By their numbers in this assay, from the lowest: compounds 4, 2, 1 and 3 (each within the scatter of the next).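

In this assay, methyl in place of vinyl on a saturated chain carbon bound to an oxygen next to a carbonyl group gives a step within the scatter (a 1.0-fold lower number from compound 2 to compound 4 (0.00 log units; within the scatter)), and methyl in place of isopropyl at the same place does likewise (a 1.1-fold lower number from compound 1 to compound 4 (0.02 log units; within the scatter)). Within the data shown here, the earlier compounds offered only the single swap of isopropyl for vinyl; compound 1, compound 2 and compound 4 now form a closed set of three chain ends in which no step lies beyond the scatter, and this includes going from allyl to ethyl, which removes the double bond outside the aromatic ring. Nothing available accounts for this flat result.

The compounds shown leave open whether a longer chain at this place would give a step beyond the scatter. The same question stands for an amine or a carboxylic acid on this chain.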